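The source may report more compounds than this note shows. Statements on the series, on what has been measured and on what is new or still open speak of the compounds shown alone.

Of the compounds shown here, three sharing one core have been measured in a functional assay on Hep 3B2 cells (Homo sapiens) for antiproliferative activity, read by MTT assay, with a stated time of 24 h, tested at 0.41 ug/mL; a higher number here means a stronger effect of the compound at the concentration tested, a lower number a weaker effect. Compound 1 `Cc1ccc2nc(C(=O)Nc3c(F)cc(-c4cccc(F)c4)cc3F)c(C)c(O)c2c1` gives 5.25%. Compound 2 `CCc1ccc2nc(C(=O)Nc3c(F)cc(-c4cccc(F)c4)cc3F)c(C)c(O)c2c1` gives 16.2%. Compound 3 `CCOc1ccc2nc(C(=O)Nc3c(F)cc(-c4cccc(F)c4)cc3F)c(C)c(O)c2c1` gives 0.26%. Among these three numbers compound 2 stands highest: the change a number 11 percentage points higher from compound 1 to compound 2 (beyond the scatter) goes beyond the scatter, as does a number 15.9 percentage points lower from compound 2 to compound 3 (beyond the scatter), while a number 5 percentage points lower from compound 1 to compound 3 (within the scatter) stays within it.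

Compound 4 `CCc1ccc2nc(C(=O)Nc3c(F)cc(-c4cccc(F)c4)cc3F)c(C)c(C(=O)O)c2c1` is not yet measured. Against compound 2 the change is carboxy in place of hydroxy on an aromatic carbon. Among the measured compounds shown here, none of the measured steps touches this position: the steps from compound 1 to compound 2 and from compound 2 to compound 3 alter a group on a different aromatic carbon, and all three measured compounds keep the hydroxy. For the measured compounds named here, the measured steps were modest in size, which suggests that single changes on this core move the read-out by modest amounts rather than large ones, but no direct precedent for exchanging the hydroxy exists here. In this assay the step for compound 4 is therefore expected to be small or modest, most likely a lowering from the highest measured number, amounting to a number 7.2 percentage points lower from compound 2 to compound 4 (within the scatter). Compound 4 is estimated at 9%, within a range from 0% to 22%.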

Compound 4, a percentage reported as inhibition, at one concentration (the size of the read-out at that concentration, not a potency): 1.68%
Estimate against measurement, compound 4: 7.3 percentage points above; the range from low to high includes it.
By their numbers in this assay, from the lowest: compounds 3, 4 and 1 (each within the scatter of the next); then compound 2.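

Among the compounds shown here, this is the first change at the aromatic carbon opposite the ring nitrogen, where all the earlier compounds keep the hydroxy, and in this assay replacing that hydroxy with carboxy gives a number 14.5 percentage points lower from compound 2 to compound 4 (beyond the scatter). For the compounds shown here, the read-out at the concentration tested therefore depends on the group at this position, not only on the group changed in the earlier steps, and here a group of three heavy atoms in place of one removes most of the effect seen with compound 2. No measurement is available to explain this drop, and hydroxy and carboxy have the same count of hydrogen-bond donors and acceptors.

The compounds shown leave open whether the loss of the hydroxy or the arrival of the carboxy matters more, and a methoxy or an amine on this carbon would help to separate the two. Also open, as far as these compounds go, is whether carboxy has a similar effect when the ethyl of compound 2 is replaced by the methyl of compound 1 or the ethoxy of compound 3.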